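This account rests on a few compounds, and the source may have more. Where it says the series, first, only, none or still open, it means among the compounds named here.

Among the compounds with values here, compound 3 `N#Cc1ccc(NC(=O)c2ccc(C(F)(F)F)cc2O)cc1` is one of three compounds measured in a functional assay on KG-1 cells (Homo sapiens) for cytotoxicity, read by luminescence and CellTiter-Glo, with a stated time of 3 days; a higher number here means a weaker inhibitor, a lower number a stronger inhibitor. In this assay compound 3 gives 1440 nM, the second highest of the three numbers. Compound 1 `O=C(Nc1ccc(C(F)(F)F)cc1)c1ccc(Cl)cc1O` gives 580 nM, and compound 2 `N#Cc1ccc(NC(=O)c2ccc(-c3cccnc3)cc2O)cc1` gives 7940 nM. Compound 1 and compound 3 differ in two places, so their values can only be set side by side without a step between them.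

Compound 4 `N#Cc1ccc(NC(=O)c2ccc(Cl)cc2O)cc1` has not yet been measured. It differs from compound 3 in one place: chloro in place of trifluoromethyl on an aromatic carbon. Within the data shown here, the only measured step at this position is a 5.5-fold lower number from compound 2 to compound 3 (0.74 log units; beyond the scatter), which concerns a different pair of groups; no measured step exchanges trifluoromethyl for chloro. Compound 1, which carries chloro on that ring, shows a number lower than compound 3, but its other ring differs as well.

Among the measured compounds shown here, with no direct precedent, the step from compound 3 to compound 4 is expected to be small, a 1.3-fold lower number from compound 3 to compound 4 (0.12 log units; within the scatter), and compound 4 is estimated at 1100 nM, with a range from 400 nM to 3500 nM.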

Compound 4, half-maximal inhibitory concentration: 1920 nM
Compound 4: the middle estimate sits 1.7-fold (0.24 log units) below what was measured, and the stated range covers the measured number.
By their numbers in this assay, from the lowest: compound 1; then compounds 3 and 4 (each within the scatter of the next); then compound 2.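

In this assay, the exchange of trifluoromethyl for chloro at this position (a 1.3-fold higher number from compound 3 to compound 4 (0.12 log units; within the scatter)) lies within the scatter, so the two groups cannot be told apart here, while chloro stands clear of pyridin-3-yl (a 4.1-fold lower number from compound 2 to compound 4 (0.62 log units; beyond the scatter)) just as trifluoromethyl does. Within the data shown here, compound 4 also gives the first single-place link to compound 1 and so the first step at a second place in the molecule, where cyano takes the place of trifluoromethyl (a 3.3-fold higher number from compound 1 to compound 4 (0.52 log units; beyond the scatter)). Nothing at hand explains any of these differences.

Open, on these data alone, is how an amine or a carboxylic acid would fare at the position held by chloro in compound 4. Also open, as far as these compounds go, is whether the step from trifluoromethyl to cyano at the second place keeps its size when that position carries a group other than chloro.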